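This account rests on a few compounds, and the source may have more. Where it says the series, first, only, none or still open, it means among the compounds named here.

Three compounds were tested in a functional assay on HT-29 cells (Homo sapiens) for cytotoxicity, read by MTT assay, with a stated time of 72 h; a lower number here means a stronger inhibitor of growth, a higher number a weaker inhibitor of growth. Compound 1 `O=C(/N=C(/NC(=O)c1cc(-c2ccccc2)nc2ccccc12)[Se]Cc1ccccc1)c1cc(-c2ccccc2)nc2ccccc12` and compound 2 `CS/C(=N\C(=O)c1cc(-c2ccccc2)nc2ccccc12)NC(=O)c1cc(-c2ccccc2)nc2ccccc12` share one core, while compound 3 `CS/C(=N\C(=O)c1cnc2ccccc2c1)NC(=O)c1cnc2ccccc2c1` is built on another; the difference between the two cores is not broken down here. In this assay compound 1 gives > 100000 nM, which is a limit of the assay rather than a number. Compound 2 likewise gives > 100000 nM, also a limit. Compound 3 gives > 100000 nM, again a limit. The change from compound 2 to compound 1 is a group of 8 heavy atoms (7 carbon, 1 selenium; one six-membered aromatic ring of carbon only) in place of a group of 2 heavy atoms (1 carbon, 1 sulfur; no ring), on a carbon with a double bond to nitrogen, and the step that the two limits leave unreadable from compound 2 to compound 1 is left unreadable by the two limits. The same kind of change, (a group of 8 heavy atoms (7 carbon, 1 selenium; one six-membered aromatic ring of carbon only) in place of a group of 2 heavy atoms (1 carbon, 1 sulfur; no ring), on a carbon with a double bond to nitrogen), turns compound 3 into compound 4 `O=C(/N=C(/NC(=O)c1cnc2ccccc2c1)[Se]Cc1ccccc1)c1cnc2ccccc2c1`, which has not yet been measured. Among the compounds with values here, with the limit of > 100000 nM in this assay, at which 3 of the 3 values shown sit, there is no measured step to lean on, and what is expected of compound 4 rests only on these limits. The step that the limit leaves unreadable from compound 3 to compound 4 is expected to be small. Compound 4 is therefore estimated at 150000 nM, between 50000 nM and 500000 nM, and is most likely to be reported as a limit once more.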

Compound 4, concentration for total growth inhibition: > 100000 nM
Compound 4: only a limit was reported; the forecaster's own chance of this, stated with the estimate: 85%; the middle value does not contradict the limit.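

In this assay compound 4 gives > 100000 nM, which is a limit and not a number. Within the data shown here, compound 3 also sits at a limit, and no step from compound 3 to compound 4 can be read. The compounds shown leave open how strongly any of them inhibits growth, and whether replacing methylsulfanyl changes it: the limit of > 100000 nM in this assay, at which 4 of the 4 values shown sit.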